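Changing the aromatic end group: two chlorines for one fluorine

The source may report more compounds than this note shows. Statements on the series, on what has been measured and on what is new or still open speak of the compounds shown alone.

Measured compounds:
compound 1, `COc1cc(C(=O)N/N=C/c2ccccc2C(F)(F)F)cc(OC)c1OC`, 52.9%
compound 2, `COc1cc(C(=O)N/N=C/c2ccccc2F)cc(OC)c1OC`, 81.8%
compound 3, `COc1cc(C(=O)N/N=C/c2cccc(C(F)(F)F)c2)cc(OC)c1OC`, 79.8%

The three measured compounds share one core and differ only in the aromatic ring attached to the carbon that carries a double bond to nitrogen. In a functional assay on PC-3 cells (Homo sapiens) for antiproliferative activity, read by MTT assay, tested at 5 uM (on this read-out lower numbers stand for a weaker effect and higher numbers for a stronger effect at the one concentration tested), compound 2 stands highest of the three numbers; compound 3 lies within the scatter of it, while compound 1 lies beyond the scatter below it. Within the data shown here, the only step between two compounds that differ in one place is a number 28.9 percentage points higher from compound 1 to compound 2 (beyond the scatter).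

Compound 4, `COc1cc(C(=O)N/N=C/c2ccc(Cl)c(Cl)c2)cc(OC)c1OC`, is not yet measured. It differs from compound 2 in one place: 3,4-dichlorophenyl in place of 2-fluorophenyl on a carbon with a double bond to nitrogen. Among the measured compounds shown here, no measured step bears directly on this change. For the measured compounds named here, the one known step compares fluoro with trifluoromethyl and says nothing about chlorine or about replacing one substituent with two. The data show only that changing the substituent on this ring can shift the read-out by a modest amount or leave it within the scatter.

The step expected in this assay from compound 2 to compound 4 is therefore small, tending slightly downward, a number 9.8 percentage points lower from compound 2 to compound 4 (within the scatter). Compound 4 is estimated at 72%, within a range from 52% to 90%.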

Compound 4, a percentage reported as inhibition, at one concentration (the size of the read-out at that concentration, not a potency): 31.6%
Compound 4: the middle estimate sits 40.4 percentage points above what was measured; measured number below the stated range.
By their numbers in this assay, from the lowest: compound 4; then compound 1; then compounds 3 and 2 (each within the scatter of the next).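

In this assay, putting 3,4-dichlorophenyl in place of 2-fluorophenyl on the carbon with a double bond to nitrogen gives a number 50.2 percentage points lower from compound 2 to compound 4 (beyond the scatter). Among these compounds, this shows that the shared core does not guarantee a strong read-out at the tested concentration, and that a change at this one place can move the number well beyond the only earlier step, a number 28.9 percentage points higher from compound 1 to compound 2 (beyond the scatter). Nothing measured here indicates what lies behind the large drop from compound 2 to compound 4.

This single change alters the halogen, the number of substituents on the ring and where they sit all at once, so the compounds shown leave open which of these differences matters; a phenyl ring carrying just one chlorine would help to separate them. Also open, from the compounds shown here alone, is how the read-out would respond to an aromatic end group carrying an amine or a carboxylic acid instead of fluorine or chlorine.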